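The compounds below may be only part of what the source reports. "The series", "measured", "known", "first", "only" and "open" are said of these compounds alone.

For the measured compounds named here, compound 2 `COc1ccc(OC)c(Sc2ccc3nnc(-c4ccsn4)n3n2)c1` is one of two compounds measured in an assay on HEK293 cells for inhibition of Leucine-rich repeat serine/threonine-protein kinase 2 (Homo sapiens), read by ELISA, with a stated time of 90 min; a higher number here means a weaker inhibitor, a lower number a stronger inhibitor. In this assay compound 2 gives 722 nM, the higher of the two numbers. The other is compound 1 `COc1cncc(-c2nnc3ccc(Sc4cc(OC)ccc4OC)nn23)c1`, which in this assay gives 440 nM; the step of a 1.6-fold higher number from compound 1 to compound 2 (0.22 log units; within the scatter) sits within the scatter, so the two compounds are not separated by these data.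

Compound 3 `COc1ccc(OC)c(Sc2ccc3nnc(-c4ccn(C)n4)n3n2)c1` has not yet been measured. It differs from compound 2 in one place: 1-methyl-1H-pyrazol-3-yl in place of 1,2-thiazol-3-yl on an aromatic carbon. Going by the values given here, the only measured step that bears on this position is the one from compound 1 to compound 2, where a different small heteroaryl group was exchanged at the same aromatic carbon of the shared core, and that exchange moved the number by an amount within the scatter. Another exchange of a small five-membered heteroaryl group at the same place is therefore expected to give a step of similar size, with no clear direction beyond the scatter: a 1.1-fold lower number from compound 2 to compound 3 (0.05 log units; within the scatter).

Compound 3 is estimated at 650 nM in this assay, within a range of 250 nM to 1700 nM.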

Compound 3, half-maximal inhibitory concentration: 2760 nM
The estimate for compound 3 lay 4.2-fold (0.63 log units) below the measured number, outside the stated range (above it).
By their numbers in this assay, from the lowest: compounds 1 and 2 (each within the scatter of the next); then compound 3.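

This position is not indifferent to the group it carries. In this assay, 1-methyl-1H-pyrazol-3-yl in place of 1,2-thiazol-3-yl gives a 3.8-fold higher number from compound 2 to compound 3 (0.58 log units; beyond the scatter), and the same group in place of 5-methoxypyridin-3-yl gives a 6.3-fold higher number from compound 1 to compound 3 (0.80 log units; beyond the scatter), so both steps are modest, beyond the scatter, and lead to a weaker inhibitor, whereas the earlier pair could not be separated. The entering group matches 1,2-thiazol-3-yl in having one five-membered aromatic ring with 2 hetero atoms and the same counts of hydrogen-bond donors and acceptors, so these shared features do not by themselves fix the number, and no measurement at hand accounts for the step.

Still open, going by these compounds, is whether the step belongs to the pyrazole ring or to its methyl group, a question that a 1H-pyrazol-3-yl group without the methyl would address. The compounds shown also leave open how this aromatic carbon would respond to an amine, a carboxylic acid or a longer alkyl chain in place of a ring.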